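The compounds below may be only part of what the source reports. "The series", "measured", "known", "first", "only" and "open" are said of these compounds alone.

Measured in a functional assay on NCI/ADR-RES cells (Homo sapiens) for antiproliferative activity, read by sulforhodamine B assay, with a stated time of 48 h; a lower number here means a stronger inhibitor of growth, a higher number a weaker inhibitor of growth:
- compound 1 `CCCCCC[C@@H](O)C/C=C\CCCCCCCC(=O)N[C@@H](C)c1ccccc1`: 1.9 ug/mL
- compound 2 `CCCCCCCC/C=C\CCCCCCCC(=O)N1CCCC1`: 0.2 ug/mL
- compound 3 `CCCCCC[C@@H](O)C/C=C\CCCCCCCC(=O)N1CCOCC1`: 29.4 ug/mL

Compound 3 has the highest number of the three, so it is the weakest growth inhibitor of the set. Compound 4 `CCCCCCCC/C=C\CCCCCCCC(=O)N1CCOCC1` differs from it by a single change: hydrogen in place of hydroxy on a saturated chain carbon bound to two saturated chain carbons. That is, hydrogen in place of hydroxy on a saturated chain carbon bound to two saturated chain carbons.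

For the measured compounds named here, no measured step isolates this change. Going by the values given here, the one step available, a 15-fold higher number from compound 1 to compound 3 (1.19 log units; beyond the scatter), alters the group on the carbonyl carbon while the hydroxy stays in place, so it shows only that this part of the molecule can move this assay strongly. The nearest evidence is compound 2, which also lacks the hydroxy and gives 0.2 ug/mL, but it differs from compound 3 at the carbonyl carbon as well. A sizeable step towards a lower number therefore seems likely, though its size is poorly defined. The expected change is a 5.9-fold lower number from compound 3 to compound 4 (0.77 log units; beyond the scatter). Compound 4 is estimated at 5 ug/mL, with an expected range of 0.7 ug/mL to 30 ug/mL.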

Compound 4, concentration for 50% growth inhibition: 3.3 ug/mL
Beside the measured number, compound 4's estimate is 1.5-fold (0.18 log units) above it; low and high end bracket the measured number.
By their numbers in this assay, from the lowest: compound 2; then compounds 1 and 4 (each within the scatter of the next); then compound 3.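

For the compounds shown here, with the morpholin-4-yl amide held fixed, replacing hydroxy with hydrogen on a saturated chain carbon bound to two saturated chain carbons gives an 8.9-fold lower number from compound 3 to compound 4 (0.95 log units; beyond the scatter) in this assay and so isolates this change for the first time. The group on the carbonyl carbon still matters once the hydroxy is absent: with the same chain on both compounds, morpholin-4-yl in place of pyrrolidin-1-yl gives a 17-fold higher number from compound 2 to compound 4 (1.22 log units; beyond the scatter) and this step is larger than the one from removing the hydroxy. Nothing available explains either step.

The compounds shown leave open whether removing the hydroxy has a similar effect on the pyrrolidin-1-yl or (1-phenylethyl)amino amides. They also do not show how a methoxy group, an amine or a ketone would compare at this carbon.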